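From 3,4-diethoxyphenyl to phenyl on the shared core

The compounds below may be only part of what the source reports. "The series", "measured", "known", "first", "only" and "open" are said of these compounds alone.

In a functional assay on DLD-1 cells (Homo sapiens) for cytotoxicity, read by MTT assay (a higher number here means a weaker inhibitor, a lower number a stronger inhibitor), compound 3 `CCOc1cc(/C=C/C(=O)C(=Cc2ccc(OCC)c(OCC)c2)C(=O)/C=C/c2ccc(O)c(OCC)c2)ccc1O` gives 3450 nM, the lowest number of the three measured compounds. Compound 2 `CCOc1cc(/C=C/C(=O)C(=Cc2ccc(O)cc2)C(=O)/C=C/c2ccc(O)c(OCC)c2)ccc1O` gives 20300 nM, and compound 1 `CCOc1cc(/C=C/C(=O)C(=Cc2ccc(OC)c(OC)c2)C(=O)/C=C/c2ccc(O)c(OCC)c2)ccc1O` gives 42000 nM. Compound 4 `CCOc1cc(/C=C/C(=O)C(=Cc2ccccc2)C(=O)/C=C/c2ccc(O)c(OCC)c2)ccc1O` awaits measurement. It differs from compound 3 by phenyl in place of 3,4-diethoxyphenyl on a double-bonded chain carbon bound to a double-bonded chain carbon, with phenyl in place of 3,4-diethoxyphenyl on a double-bonded chain carbon bound to a double-bonded chain carbon.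

All three measured steps change this same place. Introducing 3,4-diethoxyphenyl gave a 5.9-fold lower number from compound 2 to compound 3 (0.77 log units; beyond the scatter) and a 12-fold lower number from compound 1 to compound 3 (1.09 log units; beyond the scatter), while 4-hydroxyphenyl in place of 3,4-dimethoxyphenyl gave a 2.1-fold lower number from compound 1 to compound 2 (0.32 log units; beyond the scatter). Going by the values given here, no measured compound carries phenyl here, so the expectation rests on these three alone. Losing the 3,4-diethoxyphenyl group is expected to move the number upward, by a modest step resembling a 5.9-fold lower number from compound 2 to compound 3 (0.77 log units; beyond the scatter) in reverse. In this assay the expected step is a 4.1-fold higher number from compound 3 to compound 4 (0.61 log units; beyond the scatter). Compound 4 is estimated at 14000 nM, with an expected range from 4500 nM to 42000 nM.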

Compound 4, half-maximal inhibitory concentration: 5060 nM
For compound 4 the middle estimate is 2.8-fold (0.44 log units) above the measured one; the range from low to high includes it.
By their numbers in this assay, from the lowest: compounds 3 and 4 (each within the scatter of the next); then compound 2; then compound 1.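

With compound 4, the earlier picture of 3,4-diethoxyphenyl as a group that lowers the number no longer holds: in this assay there is a 1.5-fold higher number from compound 3 to compound 4 (0.17 log units; within the scatter), so the plain phenyl and the 3,4-diethoxyphenyl group cannot be told apart at this position. Going by these compounds alone, the same plain phenyl gives a 4.0-fold lower number from compound 2 to compound 4 (0.60 log units; beyond the scatter) and an 8.3-fold lower number from compound 1 to compound 4 (0.92 log units; beyond the scatter), which recasts the earlier steps: the hydroxy of compound 2 and the two methoxy groups of compound 1 stand with higher numbers than the ring with no substituent, while the two ethoxy groups of compound 3 do not. No evidence available here accounts for this difference between the substituents.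

As far as these compounds go, it remains open whether a single ethoxy group, or a longer chain such as propoxy, would behave like the two ethoxy groups. From the compounds shown here alone, it is equally open whether an amine or a carboxylic acid on this ring would leave the number where compound 4 has it or raise it.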